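The compounds below may be only part of what the source reports. "The series", "measured", "known", "first", "only" and "open" are said of these compounds alone.

Three related compounds have been tested in a functional assay on PANC-1 cells (Homo sapiens) for cytotoxicity, read by MTT assay, with a stated time of 72 h; a higher number here means a weaker inhibitor, a lower number a stronger inhibitor. Compound 1 `O=C1C(Nc2cccc(-c3ccccc3)c2)=CC(=O)c2ncncc21` gives 2300 nM, compound 2 `O=C1C(Nc2ccc(C3CCCCC3)cc2)=CC(=O)c2ncncc21` gives 900 nM, and compound 3 `CC1=C(Nc2ccc(N3CCN(C)CC3)cc2)C(=O)c2cncnc2C1=O` gives 380 nM. Compound 2 therefore holds the middle place among these three numbers, with compound 3 lower and compound 1 higher, and both gaps lie beyond the usual scatter of repeated measurements.

Compound 4 `O=C1C(Nc2ccc(-c3cc(Cl)cc(Cl)c3)cc2)=CC(=O)c2ncncc21` has not yet been measured. It differs from compound 2 in one group: 3,5-dichlorophenyl in place of cyclohexyl on an aromatic carbon. The 3,5-dichlorophenyl stands in place of cyclohexyl on an aromatic carbon, para to a large group.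

Among the compounds with values here, no two tested compounds differ in just one place, so no measured step shows what a swap like this does. Within the data shown here, the only hint is compound 1, which also carries an additional aromatic ring and gives 2300 nM, but it differs from compound 2 in more than that ring, so the hint is weak. A modest move toward a higher number, meaning a somewhat weaker inhibitor, is expected, and it may well stay within the scatter. The expected change is a 1.7-fold higher number from compound 2 to compound 4 (0.22 log units; within the scatter). In this assay, compound 4 is estimated at 1500 nM, with an expected range of 450 nM to 4500 nM.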

Compound 4, half-maximal inhibitory concentration: 1900 nM
Compound 4: middle estimate off by 1.3-fold (0.10 log units), on the low side; measured number inside the range.
By their numbers in this assay, from the lowest: compound 3; then compound 2; then compounds 4 and 1 (each within the scatter of the next).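

In this assay, within the data shown here, placing 3,5-dichlorophenyl in place of cyclohexyl on an aromatic carbon, para to a large group, gives a 2.1-fold higher number from compound 2 to compound 4 (0.32 log units; beyond the scatter), and this is the first step in the set where only one place changes. It shows that this position is sensitive to the swap, yet the change is modest: an aromatic ring bearing two chlorines costs a little against the non-aromatic ring of carbon, and compound 4 remains active at a level that can still be measured in the assay. Nothing measured here explains why the number rises.

The ring type and the two chlorines change together in this single step, so the compounds shown cannot tell which of them accounts for the shift, and a phenyl ring without chlorines at this place would separate the two. From the compounds shown here alone, how a carboxylic acid or a morpholine at the same carbon would compare also remains open, as does the effect of each change that sets compound 3 apart from compound 2, since those two differ in more than one place.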